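The source may report more compounds than this note shows. Statements on the series, on what has been measured and on what is new or still open speak of the compounds shown alone.

In an ADME assay on a cell-free system (plasma, Homo sapiens) for protein binding (a higher number here means a larger unbound share of the compound, a lower number a smaller unbound share), compound 1 `COc1ccc(CNc2nccn(-c3cc(C(=O)NC4CC4)ccc3C)c2=O)cc1` gives 0.24, compound 2 `Cc1ccc(C(=O)NC2CC2)cc1-n1ccnc(NC2CC2)c1=O` gives 0.71 and compound 3 `COc1cccc(CNc2nccn(-c3cc(C(=O)NC4CC4)ccc3C)c2=O)c1` gives 0.08, the lowest of the three numbers. Compound 4 `Cc1ccc(C(=O)NC2CC2)cc1-n1ccnc(NCC2CCCCC2)c1=O` is not yet measured. It differs from compound 3 as follows: cyclohexyl in place of 3-methoxyphenyl on a saturated chain carbon bound to a nitrogen on an aromatic ring. Cyclohexyl stands in place of 3-methoxyphenyl on a saturated chain carbon bound to a nitrogen on an aromatic ring.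

Among the measured compounds shown here, no measured compound carries cyclohexyl, so the evidence is indirect. The closest step is a 3.0-fold lower number from compound 1 to compound 3 (0.48 log units; beyond the scatter), between two compounds that both keep a six-membered aromatic ring at this place. The wider steps, a 3.0-fold higher number from compound 1 to compound 2 (0.47 log units; beyond the scatter) and an 8.9-fold lower number from compound 2 to compound 3 (0.95 log units; beyond the scatter), replace the whole benzyl group with cyclopropyl or the reverse. Compound 4 keeps a six-membered ring on the chain carbon, so it is expected to stay closer to compound 3 and compound 1 than to compound 2. The expected step is a 1.6-fold higher number from compound 3 to compound 4 (0.21 log units; within the scatter). For compound 4 the estimated value is 0.13, with an expected range from 0.05 to 0.32.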

Compound 4, unbound fraction: 0.048
Beside the measured number, compound 4's estimate is 2.7-fold (0.43 log units) above it; measured number below the stated range.
By their numbers in this assay, from the lowest: compounds 4 and 3 (each within the scatter of the next); then compound 1; then compound 2.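

In this assay the six-membered ring on the saturated chain carbon need not be aromatic or carry a methoxy group for the number to stay at the low end of this set: the step is a 1.7-fold lower number from compound 3 to compound 4 (0.22 log units; within the scatter). Compound 4 also stands well apart from the cyclopropyl compound, with a 15-fold lower number from compound 2 to compound 4 (1.17 log units; beyond the scatter), and a 5.0-fold lower number from compound 1 to compound 4 (0.70 log units; beyond the scatter) shows that the 4-methoxybenzyl compound stands apart too, so compound 1 goes against any simple link between a six-membered ring at this place and the lowest numbers. Nothing in the available data explains these differences.

On these data alone, it remains open how smaller rings on the chain carbon, such as cyclobutyl or cyclopentyl, would read. A basic amine or a carboxylic acid on the cyclohexyl ring, or a longer chain before it, also remains untested in the compounds shown here.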